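Trifluoromethyl to cyanomethyl on the side chain

The source may report more compounds than this note shows. Statements on the series, on what has been measured and on what is new or still open speak of the compounds shown alone.

Compound 1 `CC(C)CCn1nc(C(=O)N[C@H]2COc3ccccc3N(C)C2=S)nc1Cc1ccccc1` gives 3640 nM
Compound 2 `CN1C(=S)[C@@H](NC(=O)c2nc(Cc3ccccc3)n(CCC(F)(F)F)n2)COc2ccccc21` gives 1550 nM

Both numbers come from a functional assay on HT-29 cells (Homo sapiens) for inhibition, read by luminescence and CellTiter-Glo, with a stated time of 24 h (on this read-out lower numbers stand for an effect already at smaller amounts and higher numbers for an effect only at larger amounts of compound), and compound 2 holds the lower of the two. Compound 3 `CN1C(=S)[C@@H](NC(=O)c2nc(Cc3ccccc3)n(CCCC#N)n2)COc2ccccc21` has not been measured yet. It keeps the rest of compound 2 but carries cyanomethyl in place of trifluoromethyl on a saturated chain carbon, two bonds along the chain from an aromatic nitrogen. Read one bond further out, 3,3,3-trifluoropropyl becomes 3-cyanopropyl. Among the measured compounds shown here, only one measured change sits at this place, the modest 2.3-fold lower number from compound 1 to compound 2 (0.37 log units; beyond the scatter), and no measured compound carries a nitrile. That makes the direction uncertain, so only a small change is expected, leaning towards a higher number. The expected size is an estimated 1.6-fold higher number from compound 2 to compound 3 (0.21 log units; within the scatter) in this assay. For compound 3 the estimated value is 2500 nM, with an expected range from 1000 nM to 6000 nM.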

Compound 3, half-maximal effective concentration: 2400 nM
Estimate against measurement, compound 3: 1.0-fold (0.02 log units) above; the measured number falls inside the stated range.
By their numbers in this assay, from the lowest: compounds 2, 3 and 1 (each within the scatter of the next, the first and the last beyond it).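

The step to the nitrile, a 1.5-fold higher number from compound 2 to compound 3 (0.19 log units; within the scatter), and the step from the isopropyl-ended chain, a 1.5-fold lower number from compound 1 to compound 3 (0.18 log units; within the scatter), both stay within the scatter in this assay, so compound 3 cannot be told apart from either of the others, even though a 2.3-fold lower number from compound 1 to compound 2 (0.37 log units; beyond the scatter) separates those two. At this position, then, cyanomethyl, which brings one hydrogen-bond acceptor where trifluoromethyl has none, is accepted without a change that can be distinguished from scatter. Nothing available explains this result.

Still open, on these data alone, is whether an amine or a carboxylic acid at the end of this chain would shift the number beyond the scatter. A longer chain ending in a nitrile is equally untested among the compounds shown here.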